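Swapping a Phenyl for a Cyclohexyl on a Sigma Ligand

The source may hold more compounds than are shown below. What is called first, only, known or untested is meant among the compounds shown, and "the series" means these compounds.

Measured compounds:
compound 1 `c1ccc(CNCCC2CCCc3sccc32)cc1` with 49 nM
compound 2 `c1ccc(CCCNCCC2CCCc3sccc32)cc1` with 132 nM

Both compounds were tested in an assay on cell membranes for displacement of a labelled ligand from Sigma non-opioid intracellular receptor 1 (Cavia porcellus), read by scintillation counting, with a stated time of 120 min; a higher number here means a weaker inhibitor, a lower number a stronger inhibitor. Compound 1 gives 49 nM in this assay, and compound 2 gives 132 nM in this assay. Of these two numbers, compound 1 has the lower one, which means it is the stronger inhibitor; the gap to compound 2 lies beyond the usual scatter of repeated measurements. Compound 1 is therefore the starting point.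

Compound 3 `c1cc2c(s1)CCCC2CCNCC1CCCCC1` has not yet been measured. It differs from compound 1 in one place: cyclohexyl in place of phenyl on a saturated chain carbon bound to an amine nitrogen. Among the measured compounds shown here, no pair of measured compounds shows a change of this kind, so there is nothing to copy a step from. The shared core and the amine stay as they are, and the group that enters has the same count of heavy atoms as the one that leaves. The expectation is therefore a step from compound 1 to compound 3 of a 1.2-fold lower number from compound 1 to compound 3 (0.09 log units; within the scatter), meaning no change beyond the scatter in either direction. Compound 3 is thus estimated at 40 nM, with a range from 12 nM to 130 nM.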

Compound 3, inhibition constant: 5 nM
For compound 3 the middle estimate is 8.0-fold (0.90 log units) above the measured one; measured number below the stated range.
By their numbers in this assay, from the lowest: compound 3; then compound 1; then compound 2.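

The step of a 9.8-fold lower number from compound 1 to compound 3 (0.99 log units; beyond the scatter) in this assay shows that this position, on a saturated chain carbon bound to an amine nitrogen, does not treat these two rings alike, even though phenyl and cyclohexyl have the same count of heavy atoms and neither carries a hydrogen-bond donor or acceptor. The change from a six-membered aromatic ring to a six-membered non-aromatic ring of carbon only is enough here to move the number well beyond the scatter in favour of cyclohexyl, which compound 1 and compound 2 could not reveal, as both carry phenyl. Nothing available explains this step, so its reason remains unknown.

The compounds shown leave open how much of the cyclohexyl ring is needed, which a cyclopentyl or a tetrahydropyranyl group at the same place could begin to answer. They also leave open whether the same swap on compound 2, with its longer chain, would give a step of similar size.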